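Extending the ethyl chain of compound 2 to pentyl

The source may hold more compounds than are shown below. What is called first, only, known or untested is meant among the compounds shown, and "the series" means these compounds.

Measured in an ADME assay on J774 cells (Mus musculus) for cytotoxicity; on this read-out lower numbers stand for an effect already at smaller amounts and higher numbers for an effect only at larger amounts of compound:
Compound 1 `COC(=O)c1c[nH]c2cc(OCCOc3ccccc3)c(OC)cc2c1=O`: > 20000 nM (a limit)
Compound 2 `CCc1cc2c(=O)c(C(=O)OC)c[nH]c2cc1OCCOc1ccccc1`: > 20000 nM (a limit)

Among the compounds with values here, neither compound has given an exact number so far, and the data stop at one shared value: the limit of > 20000 nM in this assay, at which 2 of the 2 values shown sit. Within the data shown here, compound 2 therefore stands at that limit, level with the only other compound measured.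

The next compound is compound 3 `CCCCCc1cc2c(=O)c(C(=O)OC)c[nH]c2cc1OCCOc1ccccc1`. It keeps the core of compound 2, and the change is propyl in place of hydrogen on a saturated chain carbon, two bonds along the chain from an aromatic carbon. Put simply, the ethyl group becomes pentyl, with propyl in place of hydrogen on a saturated chain carbon, two bonds along the chain from an aromatic carbon.

Among the measured compounds shown here, only one measured step bears on this change, and it swaps a methoxy group for ethyl rather than lengthening a chain. Because a step that the two limits leave unreadable from compound 1 to compound 2 has no readable size, no shift in either direction can be argued for in this assay, and another limit is the likeliest result. The expected size of the change is a number no higher from compound 2 to compound 3 (the limit leaves the size open). For compound 3 the estimated value is 20000 nM, within an expected range of 10000 nM to 40000 nM.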

Compound 3, half-maximal effective concentration: > 20000 nM
Compound 3 gave a limit, no number (the forecaster's own chance of this, stated with the estimate: 75%); the middle value lies on the limit itself.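

In this assay, within the data shown here, compound 1, compound 2 and compound 3 each give only a limit and not a number, and no step between them can be read. The compounds shown leave open where each one truly lies beyond that limit, and whether the change from ethyl to pentyl shifts this read-out at all.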